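Swapping fluoro for chloro on a nitro-substituted enone scaffold

The compounds below may be only part of what the source reports. "The series", "measured", "known", "first", "only" and "open" are said of these compounds alone.

For the measured compounds named here, in a functional assay on CCRF-CEM cells (Homo sapiens) for cytotoxicity, with a stated time of 72 h (on this read-out lower numbers stand for stronger inhibition and higher numbers for weaker inhibition), compound 2 `O=C1/C(=C/c2ccc(F)cc2)CCC/C1=C\c1cccc([N+](=O)[O-])c1` gives 5050 nM, the highest of the two numbers known; compound 1 `O=C1/C(=C/c2ccccc2)CCC/C1=C\c1cccc([N+](=O)[O-])c1` gives 2290 nM. Going by the values given here, the only measured step, a 2.2-fold higher number from compound 1 to compound 2 (0.34 log units; beyond the scatter), concerns fluoro in place of hydrogen, not the change now in question. Compound 3 `O=C1/C(=C/c2ccc(Cl)cc2)CCC/C1=C\c1cccc([N+](=O)[O-])c1` differs from compound 2 by chloro in place of fluoro on an aromatic carbon. Among the compounds with values here, with no measured step for chloro in place of fluoro, the account expects compound 3 to show a step of a 1.0-fold lower number from compound 2 to compound 3 (0.00 log units; within the scatter), within the scatter. Compound 3 is therefore estimated at 5000 nM, between 2000 nM and 12500 nM.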

Compound 3, half-maximal inhibitory concentration: 1750 nM
Estimate against measurement, compound 3: 2.9-fold (0.46 log units) above; the whole stated range lies above it.
By their numbers in this assay, from the lowest: compounds 3 and 1 (each within the scatter of the next); then compound 2.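

In this assay, for the compounds shown here, the two halogens do not behave alike at this position (a 2.9-fold lower number from compound 2 to compound 3 (0.46 log units; beyond the scatter)), whereas the earlier compounds showed only fluoro against hydrogen. Chloro in place of hydrogen, by contrast, gives a step that stays within the scatter (a 1.3-fold lower number from compound 1 to compound 3 (0.12 log units; within the scatter)), so the higher number seen with fluoro does not extend to chloro. Nothing available explains this difference between the halogens.

Going by these compounds, whether bromo, methoxy or an amine at this place would read like chloro or like fluoro remains open. So does whether the same exchange of halogens would give a similar step on the ring carrying the nitro group.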